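This account rests on a few compounds, and the source may have more. Where it says the series, first, only, none or still open, it means among the compounds named here.

Working notes on the series

The series is followed in a functional assay on NCI-H23 cells (Homo sapiens) for cytotoxicity, read by sulforhodamine B assay, with a stated time of 48 h; a lower number here means a stronger inhibitor of growth, a higher number a weaker inhibitor of growth. Of the compounds shown here, two have a number so far. Compound 1 `ClCc1cccc(Cn2cnc3c(Cl)nc(Cl)nc32)c1` gives 2130 nM in this assay. Compound 2 `Nc1nc(Cl)c2ncn(Cc3ccccc3CCl)c2n1` gives 3020 nM in this assay. Of the two numbers, compound 2 has the highest; its nearest neighbour is compound 1, and the gap between the two is within the scatter, so no order between compound 1 and compound 2 can be read from them.

Compound 3 `ClCc1ccccc1Cn1cnc2c(Cl)ncnc21` has not yet been measured in this assay. Compound 3 differs from compound 2 in one place: hydrogen in place of amino on an aromatic carbon. Going by the values given here, no measured pair shows the effect of a change of this kind, so nothing in the two numbers at hand points in either direction. The expectation for the step from compound 2 to compound 3 is therefore one that stays within the scatter, a 1.1-fold lower number from compound 2 to compound 3 (0.03 log units; within the scatter), with the range kept wide. On that basis compound 3 is estimated at 2800 nM in this assay, expected to fall between 1000 nM and 8000 nM.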

Compound 3, concentration for 50% growth inhibition: 2040 nM
Beside the measured number, compound 3's estimate is 1.4-fold (0.14 log units) above it; low and high end bracket the measured number.
By their numbers in this assay, from the lowest: compounds 3, 1 and 2 (each within the scatter of the next).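

The amino group on this aromatic carbon, between two ring nitrogen atoms, can be replaced by hydrogen without a readable effect in this assay: the step is a 1.5-fold lower number from compound 2 to compound 3 (0.17 log units; within the scatter). Going by these compounds alone, this is the first measured pair to isolate a change at this position, and it shows that growth inhibition of this order does not depend on the amino group in this pair, as compound 3 stays level with compound 2 within the scatter even without the hydrogen-bond donor and acceptor counted for that group. No separate measurement bears on why the two compounds read alike, so the pair records the outcome of the change and nothing about its origin.

This is a single pair on one core, so it cannot be said whether the same change would read alike with a different group at the chloro position or on another form of the shared core. The compounds shown also leave open what a larger group on this aromatic carbon, such as dimethylamino or methoxy, would do to the number.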